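This account rests on a few compounds, and the source may have more. Where it says the series, first, only, none or still open, it means among the compounds named here.

In a functional assay on MCF7 cells (Homo sapiens) for cytotoxicity, read by MTT assay, with a stated time of 48 h (a lower number here means a stronger inhibitor, a higher number a weaker inhibitor), two compounds of this series have been measured. Compound 1 `C=CC(=C)CC[C@@H]1[C@@]2(C)CCC[C@](C)(COC(=O)/C=C/c3ccc(O)c(OC)c3)[C@@H]2CC[C@@]1(C)O` gives 13500 nM in this assay, a weak inhibitor by any reckoning. Compound 2 `C=C[C@@](C)(O)CC[C@H]1C(=C)CC[C@@H]2[C@]1(C)CCC[C@]2(C)C(=O)O` is known only as a limit of this assay, reported as > 40000 nM, so no number can be placed on it. Compound 2 therefore stands at the weak edge of what this assay can report (the limit of > 40000 nM in this assay, at which 1 of the 2 values shown sits), the weaker of the two results shown, while compound 1 sits within range. Compound 3 `C=C[C@]1(C)O[C@H]1C[C@H]1C(=C)CC[C@@H]2[C@]1(C)CCC[C@]2(C)C(=O)O` has not yet been measured in this assay. It differs from compound 2 in one place: a group of 6 heavy atoms (5 carbon, 1 oxygen; one three-membered non-aromatic ring with 1 hetero atom) in place of a group of 6 heavy atoms (5 carbon, 1 oxygen; no ring), on a saturated chain carbon bound to a saturated ring carbon.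

For the measured compounds named here, no measured step between compounds that differ in one place is available, and since compound 2 is a limit, the step from compound 2 to compound 3 cannot be anchored to a number. The expected step of an at least 1.3-fold lower number from compound 2 to compound 3 (0.12 log units; that floor lies within the scatter) is a small one toward stronger inhibition, no more than the usual scatter. Compound 3 is thus expected to give about 30000 nM in this assay, with a plausible range from 8000 nM to 80000 nM.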

Compound 3, half-maximal inhibitory concentration: > 40000 nM
Compound 3: only a limit was reported; the forecaster's own chance of this, stated with the estimate: 45%; middle value at least 1.3-fold (0.12 log units) away from the limit.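

In this assay compound 3 gives > 40000 nM, which is a limit and not a number. Compound 2 is also known only as a limit, so no step can be read between compound 2 and compound 3: the limit of > 40000 nM in this assay, at which 2 of the 3 values shown sit.

The compounds shown leave open whether the three-membered ring group, in place of the 2-hydroxy-2-methylbut-3-en-1-yl group, changes cytotoxicity at all.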